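Removing the ring methyl from compound 1

The source may hold more compounds than are shown below. What is called first, only, known or untested is meant among the compounds shown, and "the series" means these compounds.

Measured so far:
- compound 1, `COC(=O)C1=C(C)NC(C)=C(C(=O)OC)C1c1c(-c2ccsc2)nc2sc(C)cn12`: 2300 nM
- compound 2, `CCOC(=O)C1=C(C)NC(C)=C(C(=O)OCC)C1c1c(-c2cc(OC)ccc2OC)nc2sccn12`: 2630 nM

Both values come from a functional assay on cardiac atrium (Cavia porcellus); a lower number here means that less compound is needed, a higher number that more compound is needed for the effect. Compound 1 has the lowest of the two numbers, but compound 2 lies close to it, within the scatter, so the two compounds cannot be ranked. Compound 2 also differs from compound 1 in several places at once, so no single step can be read from the pair.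

Compound 3, `COC(=O)C1=C(C)NC(C)=C(C(=O)OC)C1c1c(-c2ccsc2)nc2sccn12`, has not been measured. Compared with compound 1 it carries hydrogen in place of methyl on an aromatic carbon; the change is on a five-membered aromatic ring of the shared core, at the carbon next to the ring sulfur. Within the data shown here, no measured pair shows what such a change does here. On the small structural difference alone, the step in this assay is expected to be small, with no direction beyond the scatter. For compound 3 the estimate is 2500 nM, within 1000 nM to 6000 nM, which means an expected step of a 1.1-fold higher number from compound 1 to compound 3 (0.04 log units; within the scatter).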

Compound 3, half-maximal effective concentration: 1060 nM
Compound 3: the middle estimate sits 2.4-fold (0.37 log units) above what was measured; low and high end bracket the measured number.
By their numbers in this assay, from the lowest: compound 3; then compounds 1 and 2 (each within the scatter of the next).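

In this assay, hydrogen in place of methyl on an aromatic carbon, next to the ring sulfur, gives a 2.2-fold lower number from compound 1 to compound 3 (0.34 log units; beyond the scatter). Among these compounds, this is the only single-place step so far, and it shows that this position affects the read-out and that the methyl is not required for the effect on the core of compound 1. No measurement at hand explains the step, so it stands as an observation only.

Whether the step holds with other substituents elsewhere on the core cannot be read, since compound 2 differs from both compound 1 and compound 3 in more than one place. As far as these compounds go, it also remains open how this position responds to a chlorine atom, an amine or a longer chain such as propyl, and whether any of these would differ from hydrogen beyond the scatter.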